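A 3-bromophenyl in place of 2-methoxyphenyl

The source may report more compounds than this note shows. Statements on the series, on what has been measured and on what is new or still open speak of the compounds shown alone.

Values measured in a functional assay on SGC-7901 cells (Homo sapiens) for inhibition, read by MTT assay, with a stated time of 24 h (on this read-out higher numbers stand for weaker inhibition and lower numbers for stronger inhibition), for three compounds:
Compound 1 `CC1(C)[C@H]2CC[C@]1(C)N(Cc1cn(-c3cccc(C#N)c3)nn1)C(=O)C2` gives 250 nM
Compound 2 `CC1(C)[C@H]2CC[C@]1(C)N(Cc1cn(-c3ccc(F)cc3)nn1)C(=O)C2` gives 500 nM
Compound 3 `COc1ccccc1-n1cc(CN2C(=O)C[C@@H]3CC[C@@]2(C)C3(C)C)nn1` gives 280 nM

Compound 3 does not stand apart from the other two compounds. Its steps read a 1.1-fold higher number from compound 1 to compound 3 (0.05 log units; within the scatter) and a 1.8-fold lower number from compound 2 to compound 3 (0.25 log units; within the scatter) on this measure. The remaining pair shows a 2.0-fold higher number from compound 1 to compound 2 (0.30 log units; within the scatter) as well, so the three values stand together.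

Going from compound 3 to compound 4 `CC1(C)[C@H]2CC[C@]1(C)N(Cc1cn(-c3cccc(Br)c3)nn1)C(=O)C2` puts 3-bromophenyl in place of 2-methoxyphenyl on an aromatic nitrogen of a five-membered aromatic ring with 3 nitrogen. Among the compounds with values here, no measured compound carries this group, so the three steps above, each a swap at this same place, are the only guide. Compound 1, with 3-cyanophenyl, gives 250 nM and offers the nearest named group. On this evidence no step beyond the scatter is expected in this assay and no direction can be given. The expected step is a 1.1-fold higher number from compound 3 to compound 4 (0.03 log units; within the scatter) and it is not expected to mean a real change. Compound 4 is estimated at 300 nM with an expected range from 130 nM to 650 nM for this compound.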

Compound 4, half-maximal inhibitory concentration: 120 nM
Compound 4: the middle estimate sits 2.5-fold (0.40 log units) above what was measured, outside the stated range (below it).
By their numbers in this assay, from the lowest: compound 4; then compounds 1, 3 and 2 (each within the scatter of the next).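

Up to this point, swapping the aryl group on the aromatic nitrogen had produced no step beyond the scatter in this assay, so the position could have seemed indifferent to the group it carries. The 3-bromophenyl group changes that reading, with a 2.3-fold lower number from compound 3 to compound 4 (0.37 log units; beyond the scatter), a 4.2-fold lower number from compound 2 to compound 4 (0.62 log units; beyond the scatter) and a 2.1-fold lower number from compound 1 to compound 4 (0.32 log units; beyond the scatter), which makes compound 4 the most potent of the four on this measure, though each step is only modest. The last of these steps is the closest comparison, as only bromo in place of cyano on an aromatic carbon separates the two compounds, showing that a change of that one substituent on the phenyl ring can be enough to move the number; nothing given here explains why this happens.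

The compounds shown leave open whether chloro or iodo in place of the bromo would hold this gain, and what an amine or a carboxylic acid on the same phenyl ring would do. As far as these compounds go, all four compounds also share one core, so the effect of any change to that core remains unknown.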